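Swapping phenyl for cyclopentyl on the amide nitrogen

The source may report more compounds than this note shows. Statements on the series, on what has been measured and on what is new or still open speak of the compounds shown alone.

Measured so far:
compound 1, `C#CCn1cc(C(=O)NC(CC(=O)Nc2ccccc2)c2ccccc2)c(=O)c2cccnc21`, > 10000 nM
compound 2, `C#CCn1cc(C(=O)NC(CC(=O)Nc2ccccc2)c2ccccc2)c(=O)c2cc(F)c(Cl)nc21`, 6600 nM

In a functional assay on K562 cells (Homo sapiens) for cytotoxicity, read by MTT assay, with a stated time of 72 h (on this read-out higher numbers stand for weaker inhibition and lower numbers for stronger inhibition), compound 1 reaches only (the limit of > 10000 nM in this assay, at which 1 of the 2 values shown sits), a limit rather than a number. Within the data shown here, compound 2 therefore holds the only numeric value shown, giving 6600 nM in this assay. Compound 3, `C#CCn1cc(C(=O)NC(CC(=O)NC2CCCC2)c2ccccc2)c(=O)c2cc(F)c(Cl)nc21`, carries one change against compound 2: cyclopentyl in place of phenyl on an amide-type nitrogen. Among the measured compounds shown here, no measured pair shows what this kind of change does here, so no direction beyond the scatter is expected. Compound 3 is estimated at 7000 nM in this assay, between 2500 nM and 20000 nM, a step of a 1.1-fold higher number from compound 2 to compound 3 (0.03 log units; within the scatter) that is expected to stay within the scatter.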

Compound 3, half-maximal inhibitory concentration: 7300 nM
Compound 3: middle estimate off by 1.0-fold (0.02 log units), on the low side; measured number inside the range.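

Among these compounds, on the amide-type nitrogen, the earlier compounds gave no pair to read, and this first pair shows a 1.1-fold higher number from compound 2 to compound 3 (0.04 log units; within the scatter) in this assay. An aromatic carbon ring and a non-aromatic carbon ring at this place therefore read alike, so the aromatic ring is not required to keep this level of activity. Nothing measured here explains that match.

On these data alone, what a methyl group, a longer chain ending in an amine, or a carboxylic acid would do at this nitrogen stays open. So does whether any group here can move the number beyond the scatter.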